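Sulfonamide Nitrogen Substituents on the Coumarin Enaminone Series

The source may hold more compounds than are shown below. What is called first, only, known or untested is meant among the compounds shown, and "the series" means these compounds.

Of the compounds shown here, two have a number so far. Compound 1 `N=C(N)NS(=O)(=O)c1ccc(N/C=C\C(=O)c2cc3ccccc3oc2=O)cc1` gives 87600 nM in a functional assay on T47D cells (Homo sapiens) for cytotoxicity, read by sulforhodamine B assay, with a stated time of 48 h (a higher number here means a weaker inhibitor, a lower number a stronger inhibitor), the higher of the two numbers; compound 2 `O=C(/C=C\Nc1ccc(S(=O)(=O)Nc2ncccn2)cc1)c1cc2ccccc2oc1=O` gives 75200 nM in this assay, and the pair lies within the scatter, as a 1.2-fold lower number from compound 1 to compound 2 (0.07 log units; within the scatter) shows. Compound 3 `Cc1cc(C)nc(NS(=O)(=O)c2ccc(N/C=C\C(=O)c3cc4ccccc4oc3=O)cc2)n1` is not yet measured. It differs from compound 1 by a group of 8 heavy atoms (6 carbon, 2 nitrogen; one six-membered aromatic ring with 2 hetero atoms) in place of a group of 3 heavy atoms (1 carbon, 2 nitrogen; no ring), on a sulfonamide nitrogen. Among the compounds with values here, the only step that bears on this change is the one from compound 1 to compound 2, where the same position took on a pyrimidin-2-yl ring without a shift beyond the scatter. Within the data shown here, the added methyl groups of compound 3 have no precedent, so no direction can be read from the data. The expected step of a 1.1-fold lower number from compound 1 to compound 3 (0.04 log units; within the scatter) is therefore none beyond the scatter, and compound 3 is estimated at 80000 nM in this assay, with a range from 30000 nM to 200000 nM.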

Compound 3, half-maximal inhibitory concentration: 62200 nM
Compound 3: the middle estimate sits 1.3-fold (0.11 log units) above what was measured; the measured number falls inside the stated range.
By their numbers in this assay, from the lowest: compounds 3, 2 and 1 (each within the scatter of the next).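

In this assay, the larger 4,6-dimethylpyrimidin-2-yl group on the sulfonamide nitrogen still brings no change beyond the scatter (a 1.4-fold lower number from compound 1 to compound 3 (0.15 log units; within the scatter)). Within the data shown here, the step that isolates the two methyl groups (a 1.2-fold lower number from compound 2 to compound 3 (0.08 log units; within the scatter)) is the first reading of substitution on the pyrimidin-2-yl ring, and it also lies within the scatter, so the three groups on this nitrogen cannot be told apart here. No measurement is available that explains this flat result.

Still open, on these data alone, is whether any group on this nitrogen can move the number beyond the scatter, for example a plain acetyl group or a phenyl ring. Also open, as far as these compounds go, is what an amine or a carboxylic acid on the pyrimidin-2-yl ring would do in place of the methyl groups.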